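The compounds below may be only part of what the source reports. "The series", "measured", "known", "first", "only" and "open" are said of these compounds alone.

Compound 2 `Cc1nnc(SCC(=O)Nc2ccc(-c3nc(-c4ccccc4)c(-c4ccccc4)n3C)cc2)s1` stands highest of the two numbers measured in a functional assay on HT-29 cells (Homo sapiens) for cytotoxicity, read by MTT assay, with a stated time of 24 h, tested at 16 ug/mL; on this read-out higher numbers stand for a stronger effect at the one concentration tested and lower numbers for a weaker effect: compound 2 gives 83.3%. Its nearest neighbour is compound 1 `Cn1c(-c2ccc(NC(=O)CSc3nc4cc(Cl)ccc4o3)cc2)nc(-c2ccccc2)c1-c1ccccc1`, which in this assay gives 42.5%. The two differ only in the group on the sulfur, and that single exchange brought a number 40.8 percentage points higher from compound 1 to compound 2 (beyond the scatter). Compound 3 `Cn1ccnc1SCC(=O)Nc1ccc(-c2nc(-c3ccccc3)c(-c3ccccc3)n2C)cc1` has not yet been measured. It differs from compound 2 at the same place: 1-methyl-1H-imidazol-2-yl in place of 5-methyl-1,3,4-thiadiazol-2-yl on a sulfur. Within the data shown here, the only measured step that bears on this change is the one from compound 1 to compound 2, which was large, so the group on the sulfur clearly shapes the read-out in this assay; no measured pair, however, shows what the 1-methyl-1H-imidazol-2-yl group does there, so the direction is uncertain. A moderate drop is nonetheless expected for compound 3, with a number 23.3 percentage points lower from compound 2 to compound 3 (beyond the scatter) as the estimated step. The estimate for compound 3 in this assay is 60%, within a range from 30% to 88%.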

Compound 3, a percentage reported as activity, at one concentration (the size of the read-out at that concentration, not a potency): 36.5%
Compound 3: middle estimate off by 23.5 percentage points, on the high side; the measured number falls inside the stated range.
By their numbers in this assay, from the lowest: compounds 3 and 1 (each within the scatter of the next); then compound 2.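

In this assay, the exchange of 5-methyl-1,3,4-thiadiazol-2-yl for 1-methyl-1H-imidazol-2-yl on the sulfur gives a number 46.8 percentage points lower from compound 2 to compound 3 (beyond the scatter), even though both groups have 6 heavy atoms and one five-membered aromatic ring. So the read-out here depends on more than ring size and heavy-atom count. Replacing 5-chloro-1,3-benzoxazol-2-yl with 1-methyl-1H-imidazol-2-yl gives a number 6 percentage points lower from compound 1 to compound 3 (within the scatter), so these two groups cannot be told apart here, and among the three groups shown only 5-methyl-1,3,4-thiadiazol-2-yl stands apart from the others.

Nothing available explains why the thiadiazole compound differs from the other two. On these data alone, it remains open whether the high number of compound 2 would survive in a close relative, such as a 5-methyl-1,3,4-oxadiazol-2-yl group, which has oxygen in place of the ring sulfur, or a 1,3,4-thiadiazol-2-yl group without the methyl.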